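A few compounds are considered here, and "the series" means these few. Any claim that something is new, unique, unknown or untested is made for them only; others in the source may bear on it.

Compound 1 `ClCc1ccc(Cn2cnc3c(Cl)ncnc32)cc1` serves as the reference point of this small set. In a functional assay on UO-31 cells (Homo sapiens) for cytotoxicity, read by sulforhodamine B assay, with a stated time of 48 h (a higher number here means a weaker inhibitor of growth, a lower number a stronger inhibitor of growth), compound 1 gives 4570 nM, the second highest of three numbers. Compound 3 `ClCc1ccc(Cn2cnc3nc(Cl)nc(Cl)c32)cc1` differs from compound 1 in more than one place. In this assay compound 3 gives 2880 nM, a value within the scatter of that of compound 1. Compound 2 `ClCc1cccc(Cn2cnc3c(Cl)ncnc32)c1`, with the chloromethyl group moved to another position of the benzyl ring, gives 36300 nM in this assay, a number that sits beyond the scatter above compound 1.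

Compound 4 `ClCc1ccc(Cn2cnc3c(Cl)nc(Cl)nc32)cc1` is not yet measured. It differs from compound 1 by chloro in place of hydrogen on an aromatic carbon. Among the measured compounds shown here, no pair of measured compounds isolates this change. Compound 3 also carries an additional chloro group on its core and gives 2880 nM, within the scatter of compound 1, so a step from compound 1 to compound 4 of a 1.5-fold lower number from compound 1 to compound 4 (0.18 log units; within the scatter) is expected, leaning toward a lower number but not clearly beyond the scatter. Compound 4 is estimated at 3000 nM, with a range from 1000 nM to 9000 nM.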

Compound 4, concentration for total growth inhibition: 35500 nM
Beside the measured number, compound 4's estimate is 12-fold (1.07 log units) below it; the measured number lies above the stated range.
By their numbers in this assay, from the lowest: compounds 3 and 1 (each within the scatter of the next); then compounds 4 and 2 (each within the scatter of the next).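

In this assay, chloro in place of hydrogen on an aromatic carbon between two ring nitrogen atoms gives a 7.8-fold higher number from compound 1 to compound 4 (0.89 log units; beyond the scatter), toward weaker inhibition of growth. The earlier compounds shown here isolated no single change on the shared core; this step shows that one added chloro group at this position is enough to move the number beyond the scatter, so the position is not indifferent to substitution. Nothing at hand explains the step.

Going by these compounds, whether the step belongs to chloro itself or would follow any replacement of this hydrogen remains open, and an amine, a methoxy group or a methyl group on the same carbon would separate those readings. Also open, on these data alone, is whether the same step would appear with the chloromethyl group placed as in compound 2.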